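Pyrrolidinyl to Piperazinyl Amide in the Writhing Test

The source may hold more compounds than are shown below. What is called first, only, known or untested is meant among the compounds shown, and "the series" means these compounds.

Measured compounds:
Compound 1, `CCCCCCNC(=O)CC1CCc2cc(OC)c(OC)cc21`: 82.2%
Compound 2, `COc1cc2c(cc1OC)C(CC(=O)N1CCCC1)CC2`: 19.2%

In a functional assay on the whole organism (strain Swiss albino) for inhibition, with Mus musculus as the target, in the writhing test, with stated times of 60 min and 15 min, at a dose of 100 mg/kg by the oral route (a higher number here means more inhibition at the dose given (going by the name of the read-out), a lower number less inhibition), compound 1 gives 82.2%, and compound 2 gives 19.2%. Among the measured compounds shown here, compound 2 stands lowest of the two numbers known; its nearest neighbour is compound 1, and the only step recorded so far, a number 63 percentage points lower from compound 1 to compound 2 (beyond the scatter), exchanged pyrrolidin-1-yl for hexylamino on the carbonyl carbon.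

Compound 3, `COc1cc2c(cc1OC)C(CC(=O)N1CCNCC1)CC2`, has not yet been measured in this assay. Its difference from compound 2 is piperazin-1-yl in place of pyrrolidin-1-yl on a carbonyl carbon. For the measured compounds named here, no measured step covers an exchange of one ring amine for another on this carbonyl carbon; the one step that exists changed an open hexyl chain into a ring, and that is a different kind of change. With only the pyrrolidinyl and hexylamino examples to go by, the account expects compound 3 to sit close to compound 2, with a step of a number 6.8 percentage points higher from compound 2 to compound 3 (within the scatter) that is expected to fall within or only slightly beyond the scatter. The estimate for compound 3 is 26%, expected between 5% and 55%.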

Compound 3, a percentage reported as inhibition, in the whole organism at one dose (the size of the read-out at that dose, not a potency): 68.8%
For compound 3 the middle estimate is 42.8 percentage points below the measured one; measured number outside the range, above it.
By their numbers in this assay, from the lowest: compound 2; then compound 3; then compound 1.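

In this assay, the exchange of one ring amine for another on this carbonyl carbon proves to be a large change in its own right (a number 49.6 percentage points higher from compound 2 to compound 3 (beyond the scatter)), something the earlier pair, which compared an open chain with a ring, could not show. The low number of compound 2 therefore cannot be read as a feature of every ring amide of the shared core, since the piperazin-1-yl ring, with its second ring nitrogen and its hydrogen-bond donor, brings the read-out much closer to that of the open hexylamino amide. A modest gap beyond the scatter still remains (a number 13.4 percentage points lower from compound 1 to compound 3 (beyond the scatter)), and nothing available bears on why these amides differ.

The compounds shown leave open whether the second ring nitrogen or the six-membered ring goes with the higher number, a question that piperidin-1-yl and morpholin-4-yl on the same carbonyl carbon would help to separate. They also leave open whether 4-methylpiperazin-1-yl keeps the number of compound 3, and how a shorter chain such as butylamino compares with hexylamino in this assay.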